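Swapping a Sulfonyl Substituent: Dimethylamino to Isobutyl

A few compounds are considered here, and "the series" means these few. Any claim that something is new, unique, unknown or untested is made for them only; others in the source may bear on it.

Measured compounds:
compound 1 `O=C([C@@H]1CCCN(S(=O)(=O)c2ccc(S(=O)(=O)C3CCC3)cc2)C1)N1CCC(F)(F)CC1`, 78 nM
compound 2 `CN(C)S(=O)(=O)c1ccc(S(=O)(=O)N2CCC[C@@H](C(=O)N3CCC(F)(F)CC3)C2)cc1`, 560 nM

Among the compounds with values here, in a functional assay on BXPC-3 cells (Homo sapiens) for inhibition, read by MTT assay, with a stated time of 7 days (on this read-out lower numbers stand for stronger inhibition and higher numbers for weaker inhibition), compound 2 gives 560 nM, the higher of the two numbers; its only neighbour is compound 1, separated by the step of a 7.2-fold higher number from compound 1 to compound 2 (0.86 log units; beyond the scatter). Compound 3 `CC(C)CS(=O)(=O)c1ccc(S(=O)(=O)N2CCC[C@@H](C(=O)N3CCC(F)(F)CC3)C2)cc1` differs from compound 2 by isobutyl in place of dimethylamino on a sulfonyl sulfur. Within the data shown here, the one measured step that bears on this change is a 7.2-fold higher number from compound 1 to compound 2 (0.86 log units; beyond the scatter), where cyclobutyl gave way to dimethylamino and the number rose well beyond the scatter. Returning to a carbon group, now isobutyl, is expected to undo part of that rise, so a step of a 3.7-fold lower number from compound 2 to compound 3 (0.57 log units; beyond the scatter) is expected. Compound 3 is therefore estimated at 150 nM, between 50 nM and 500 nM.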

Compound 3, half-maximal inhibitory concentration: 311 nM
The estimate for compound 3 lay 2.1-fold (0.32 log units) below the measured number; low and high end bracket the measured number.
By their numbers in this assay, from the lowest: compound 1; then compounds 3 and 2 (each within the scatter of the next).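

In this assay, the step of a 1.8-fold lower number from compound 2 to compound 3 (0.26 log units; within the scatter) shows that isobutyl and dimethylamino on this sulfonyl sulfur cannot be told apart. Carbon in place of nitrogen at this point therefore does not by itself bring back the number of compound 1, and the step of a 4.0-fold higher number from compound 1 to compound 3 (0.60 log units; beyond the scatter) sets cyclobutyl apart from isobutyl as well. No measurement at hand explains why cyclobutyl stands apart. From the compounds shown here alone, whether cyclopropyl or cyclopentyl on the same sulfur would match cyclobutyl, and whether a straight butyl chain would track isobutyl, remains open.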